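The compounds below may be only part of what the source reports. "The series", "measured", "known", "first", "only" and "open" are said of these compounds alone.

Compound 1, `O=c1cc(-c2ccccc2)oc2cc(O)c(OCCCN3CCCCC3)c(O)c12` — in a functional assay on A549 cells (Homo sapiens) for antiproliferative activity, read by MTT assay, with a stated time of 48 h (on this read-out higher numbers stand for weaker inhibition and lower numbers for stronger inhibition), compound 1 reaches only the limit > 100000 nM, which is a limit of the assay and not a number.
Compound 2, `O=c1cc(-c2ccccc2)oc2cc(O)c(OCCCCN3CCCCC3)c(O)c12` — compound 2 gives 75000 nM.
Compound 3, `COc1cc2oc(-c3ccccc3)cc(=O)c2c(O)c1OCCCCN1CCN(C)CC1` — compound 3 gives 32000 nM.

Of the two values that are numbers, compound 3 holds the lower one, and its gap to compound 2 lies beyond the scatter. Compound 1 sits at the assay limit, (the limit of > 100000 nM in this assay, at which 1 of the 3 values shown sits).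

Compound 4, `CN1CCN(CCCCOc2c(O)cc3oc(-c4ccccc4)cc(=O)c3c2O)CC1`, is not yet measured. It differs from compound 3 in one place: hydrogen in place of methyl on an oxygen on an aromatic ring; cut one bond further out, the change reads methoxy to hydroxy.

For the measured compounds named here, only one measured step is available, an at least 1.3-fold lower number from compound 1 to compound 2 (0.12 log units; that floor lies within the scatter), and it concerns the length of the chain between the ring oxygen and the piperidine, not an oxygen substituent on the core. Going by the values given here, no measured step therefore bears on the change from compound 3 to compound 4, and the expectation rests on compound 3 alone. Since compound 3 gives 32000 nM and nothing in the measured steps points in either direction, the estimate for compound 4 is a step of no more than the usual scatter, a 1.1-fold lower number from compound 3 to compound 4 (0.03 log units; within the scatter). Compound 4 is thus expected to give about 30000 nM, with a range from 10000 nM to 90000 nM.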

Compound 4, half-maximal inhibitory concentration: > 100000 nM
Compound 4 was reported as a limit (the forecaster's own chance of this, stated with the estimate: 10%); middle value at least 3.3-fold (0.52 log units) away from the limit.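

In this assay, hydrogen in place of methyl on an oxygen on an aromatic ring gives an at least 3.1-fold higher number from compound 3 to compound 4 (0.49 log units; beyond the scatter), the first step shown at this position, and it points to weaker inhibition with the methoxy form holding the better result. The amine side reads less clearly, since 4-methylpiperazin-1-yl in place of piperidin-1-yl with hydroxy at this position gives an at least 1.3-fold higher number from compound 2 to compound 4 (0.12 log units; that floor lies within the scatter), and that floor does not set the two amines in order. Compound 4 stands at a limit of the assay and not at a number, so the step that joins it to compound 1 cannot be read, with both sitting at the same limit: the limit of > 100000 nM in this assay, at which 2 of the 4 values shown sit.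

The compounds shown leave open how far the loss from methoxy to hydroxy really goes, since only its floor can be read. They also leave open whether an ethoxy group in place of the methoxy would hold or change the result, and whether a morpholine on the chain would behave like the 4-methylpiperazin-1-yl group of compound 3.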